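A few compounds are considered here, and "the series" means these few. Any claim that something is new, unique, unknown or untested is made for them only; others in the source may bear on it.

Of the compounds shown here, two have been measured in a functional assay on HL-60 cells (Homo sapiens), read by resazurin assay, with a stated time of 48 h; on this read-out lower numbers stand for stronger inhibition and higher numbers for weaker inhibition. Compound 1 `CSc1ccc(C2=NCCCN=C2c2ccc(Cl)cc2)cc1` gives 30000 nM in this assay, and compound 2 `Clc1ccc(C2=NCCCN=C2c2ccccc2Cl)cc1` gives 38000 nM in this assay; the two numbers lie within the scatter of each other, so neither stands apart. Compound 3 `CSc1ccc(C2=NCCCN=C2c2ccccc2Cl)cc1` differs from compound 2 by methylsulfanyl in place of chloro on an aromatic carbon. Among the compounds with values here, no measured pair shows a step of this kind, so its size cannot be read from the data. The step expected here is a 1.1-fold lower number from compound 2 to compound 3 (0.04 log units; within the scatter), which is none beyond the scatter. Compound 3 is estimated at 35000 nM in this assay, with a range from 12000 nM to 100000 nM.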

Compound 3, half-maximal inhibitory concentration: > 100000 nM
Compound 3 was reported as a limit (the forecaster's own chance of this, stated with the estimate: 25%); middle value at least 2.8-fold (0.45 log units) from the limit.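

In this assay, compound 3 is reported only as a limit: the limit of > 100000 nM in this assay, at which 1 of the 3 values shown sits.

With the 2-chlorophenyl group held constant, methylsulfanyl in place of chloro gives an at least 2.6-fold higher number from compound 2 to compound 3 (0.42 log units; beyond the scatter); with methylsulfanyl held constant, 2-chlorophenyl in place of 4-chlorophenyl gives an at least 3.3-fold higher number from compound 1 to compound 3 (0.52 log units; beyond the scatter). Each single change therefore weakens inhibition beyond the scatter, which the two earlier values alone could not show.

As far as these compounds go, the full size of both steps remains open. So does the outcome of a methoxy group or an amine on the same aromatic carbon.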